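A few compounds are considered here, and "the series" means these few. Any claim that something is new, unique, unknown or untested is made for them only; others in the source may bear on it.

The compounds share one core carrying four bromines; they differ only in the chain on the triazole nitrogen. Compound 1 `C[C@H](O)CCn1nc2c(Br)c(Br)c(Br)c(Br)c2n1` carries a 3-hydroxybutyl chain, and in a functional assay on MCF7 cells (Homo sapiens) for antiproliferative activity, read by MTT assay, with a stated time of 48 h, tested at 12.5 uM (on this read-out higher numbers stand for a weaker effect at the one concentration tested and lower numbers for a stronger effect), compound 1 gives 100%. Compound 2 `OC(CCn1nc2c(Br)c(Br)c(Br)c(Br)c2n1)c1ccc(Br)cc1` gives 107% in this assay, and compound 3 `OC(CCn1nc2c(Br)c(Br)c(Br)c(Br)c2n1)c1ccc(Cl)cc1` gives 100%. For the measured compounds named here, the one single-point step among them, a number 7 percentage points lower from compound 2 to compound 3 (within the scatter), is a halogen swap on an aromatic carbon far from the chain. Compound 1 is level with compound 3 at the digits reported, the two together the lowest of the three numbers, and compound 2 sits a number within the scatter of it. All three values lie close to one another.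

Compound 4 `OCC(O)Cn1nc2c(Br)c(Br)c(Br)c(Br)c2n1` is reached from compound 1 by the change (1,2-dihydroxyethyl in place of 2-hydroxypropyl on a saturated chain carbon bound to an aromatic nitrogen). Going by the values given here, no measured step touches the hydroxyl-bearing chain, so nothing among the measured compounds speaks directly to this change; the only measured step, a number 7 percentage points lower from compound 2 to compound 3 (within the scatter), concerns a different place and is within the scatter. Given that compound 1 gives 100% and the other chains give values within the scatter of it, compound 4 is expected to give 100%, between 88% and 112%, in this assay. The expected step is no change at the digits printed from compound 1 to compound 4 (within the scatter), none beyond the scatter.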

Compound 4, a percentage reported as activity, at one concentration (the size of the read-out at that concentration, not a potency): 116%
Beside the measured number, compound 4's estimate is 16 percentage points below it; measured number outside the range, above it.
By their numbers in this assay, from the lowest: compounds 1, 3, 2 and 4 (each within the scatter of the next, the first and the last beyond it).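

In this assay, putting 1,2-dihydroxyethyl in place of 2-hydroxypropyl on a saturated chain carbon bound to an aromatic nitrogen gives a number 16 percentage points higher from compound 1 to compound 4 (beyond the scatter), a modest shift towards a weaker effect. For the compounds shown here, this shows that the read-out can respond to a change in this chain, which the only earlier step, a number 7 percentage points lower from compound 2 to compound 3 (within the scatter), a halogen swap on an aromatic carbon, did not show. Nothing available explains the shift.

Going by these compounds alone, the single step changes several things at once, as 3-hydroxybutyl becomes 2,3-dihydroxypropyl, with 2 hydrogen-bond donors in place of 1 and no defined stereocentre, so the part each plays stays open. Going by these compounds, it also remains open how an amine, a carboxylic acid or a longer chain without a hydroxyl would behave at this place.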